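Swapping the aryl group on a sulfonamide: a forecast

This account rests on a few compounds, and the source may have more. Where it says the series, first, only, none or still open, it means among the compounds named here.

Measured so far:
compound 1 `Cc1nc(Cl)sc1S(=O)(=O)N1CCC(N2CCC(C)CC2)CC1` gives 1.6 nM
compound 2 `CC1CCN(C2CCN(S(=O)(=O)c3cccc(Br)c3)CC2)CC1` gives 3.2 nM

Both were measured in a functional assay on DLD-1 cells (Homo sapiens) for antiproliferative activity, read by CellTiter-Glo, with a stated time of 72 h; on this read-out lower numbers stand for stronger inhibition and higher numbers for weaker inhibition. Compound 2 holds the highest of the two numbers, with compound 1 the nearest at a 2.0-fold higher number from compound 1 to compound 2 (0.30 log units; within the scatter), a step that the data mark as within the scatter.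

Compound 3 `CC1CCN(C2CCN(S(=O)(=O)c3ccc(Cl)c(Cl)c3)CC2)CC1` has not yet been measured. It differs from compound 2 by 3,4-dichlorophenyl in place of 3-bromophenyl on a sulfonyl sulfur. For the measured compounds named here, the only step that touches this same place is the one from compound 1 to compound 2, which exchanged the whole group on the sulfonyl sulfur and stayed within the scatter. Going by the values given here, no measured step tests a change of halogen pattern on the phenyl ring itself. The expectation is therefore no step beyond the scatter in this assay, with the range widened to admit a modest move either way.

Compound 3 is thus expected to give about 3 nM, between 1 nM and 10 nM. From compound 2 the estimated step is a 1.1-fold lower number from compound 2 to compound 3 (0.03 log units; within the scatter).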

Compound 3, half-maximal inhibitory concentration: 2.9 nM
Compound 3: middle estimate off by 1.0-fold (0.01 log units), on the high side; low and high end bracket the measured number.
By their numbers in this assay, from the lowest: compounds 1, 3 and 2 (each within the scatter of the next).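

In this assay, 3,4-dichlorophenyl in place of 3-bromophenyl on the sulfonyl sulfur gives a 1.1-fold lower number from compound 2 to compound 3 (0.04 log units; within the scatter), so this change within a phenyl group, which the earlier pair did not test, produces no step beyond the scatter. Set against the thiazole group of compound 1, the same 3,4-dichlorophenyl group gives a 1.8-fold higher number from compound 1 to compound 3 (0.26 log units; within the scatter), which makes three different groups at this place that all lie within the scatter of one another. Nothing measured here offers an explanation for how closely these numbers agree.

Going by these compounds, all three groups are aromatic rings carrying halogen, so it remains open whether a group of another kind, such as a butyl chain or a phenyl ring bearing a carboxylic acid, would keep the number this low. The compounds shown also mark no limit to what this position accepts.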